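A Second Chlorine on the Benzamide Ring

The source may hold more compounds than are shown below. What is called first, only, known or untested is meant among the compounds shown, and "the series" means these compounds.

Compound 1 `Nc1ccccc1NC(=O)c1ccc(CNC(=O)c2n[nH]cc2NC(=O)c2ccccc2F)cc1` is the weaker of the two measured compounds in a functional assay on HCT-116 cells (Homo sapiens) for inhibition, read by CCK-8 assay, with a stated time of 72 h; a lower number here means a stronger inhibitor, a higher number a weaker inhibitor: compound 1 gives 4800 nM, the highest of the two numbers recorded so far. Its nearest neighbour is compound 2 `Nc1ccccc1NC(=O)c1ccc(CNC(=O)c2n[nH]cc2NC(=O)c2ccccc2Cl)cc1`, which in this assay gives 900 nM; the step of a 5.3-fold lower number from compound 1 to compound 2 (0.73 log units; beyond the scatter) arises from chloro in place of fluoro on an aromatic carbon.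

Compound 3 `Nc1ccccc1NC(=O)c1ccc(CNC(=O)c2n[nH]cc2NC(=O)c2c(Cl)cccc2Cl)cc1` has not yet been measured. It differs from compound 1 as follows: 2,6-dichlorophenyl in place of 2-fluorophenyl on a carbonyl carbon. The change thus contains the one seen on the way to compound 2, with a second chloro added to the same ring. For the measured compounds named here, only the step of a 5.3-fold lower number from compound 1 to compound 2 (0.73 log units; beyond the scatter) bears on it, and that step was modest but beyond the scatter. In this assay compound 3 is therefore expected to show a step of a 6.9-fold lower number from compound 1 to compound 3 (0.84 log units; beyond the scatter), the second chlorine remaining an open question. The estimate for compound 3 in this assay is 700 nM, within a range from 200 nM to 2500 nM.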

Compound 3, half-maximal inhibitory concentration: 710 nM
For compound 3 the middle estimate is 1.0-fold (0.01 log units) below the measured one; the range from low to high includes it.
By their numbers in this assay, from the lowest: compounds 3 and 2 (each within the scatter of the next); then compound 1.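

In this assay the full exchange of 2-fluorophenyl for 2,6-dichlorophenyl on the carbonyl carbon gives a 6.8-fold lower number from compound 1 to compound 3 (0.83 log units; beyond the scatter), so a ring carrying two chlorines keeps the lower number that one chlorine had already given. The new information lies in the second chlorine: adding it to the ring gives a 1.3-fold lower number from compound 2 to compound 3 (0.10 log units; within the scatter), a step within the scatter, so compound 2 and compound 3 cannot be told apart here, while each stands clearly apart from compound 1. The data offer nothing that would explain either the step from fluoro to chloro or the absence of a resolved step for the second chlorine.

As far as these compounds go, it remains open whether the level reached with chlorine depends on chlorine itself, since a 2,6-difluorophenyl, a bromine, a methyl group, a methoxy group or an amine on this ring would each put that to the test. It also remains open whether the pattern among these three compounds would hold in any other cell line, because all of the numbers here come from a single assay.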